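Swapping the aniline substituent in a lactam series

This account rests on a few compounds, and the source may have more. Where it says the series, first, only, none or still open, it means among the compounds named here.

Compound 2 `O=C(C1=C(Nc2ccc(F)cc2)C(=O)N(CCCn2ccnc2)C1c1ccc(Br)cc1)c1ccccc1` is tested in a functional assay on SAOS-2 cells (Homo sapiens) for antiproliferative activity, read by MTT assay, with a stated time of 72 h; a lower number here means a stronger inhibitor, a higher number a weaker inhibitor; compound 2 gives 32700 nM, which is the higher of the two numbers in hand, and its nearest neighbour is compound 1 `O=C(C1=C(Nc2ccccc2)C(=O)N(CCCn2ccnc2)C1c1ccc(Br)cc1)c1ccccc1`, for which compound 1 gives 24400 nM. Within the data shown here, the one comparison available, a 1.3-fold higher number from compound 1 to compound 2 (0.13 log units; within the scatter), is small. Compound 3 `O=C(C1=C(Nc2cccc(Br)c2)C(=O)N(CCCn2ccnc2)C1c1ccc(Br)cc1)c1ccccc1` carries 3-bromophenyl in place of 4-fluorophenyl on an amine nitrogen. Among the measured compounds shown here, only that small step bears on this change, so no shift beyond the usual scatter is expected in this assay, giving an expected 1.1-fold lower number from compound 2 to compound 3 (0.04 log units; within the scatter). Compound 3 is therefore estimated at 30000 nM, within 10000 nM to 90000 nM.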

Compound 3, half-maximal inhibitory concentration: 9090 nM
Beside the measured number, compound 3's estimate is 3.3-fold (0.52 log units) above it, outside the stated range (below it).
By their numbers in this assay, from the lowest: compound 3; then compounds 1 and 2 (each within the scatter of the next).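

The aryl group on the amine nitrogen can clearly shift the number in this assay: adding bromo to the plain phenyl ring gives a 2.7-fold lower number from compound 1 to compound 3 (0.43 log units; beyond the scatter), and 3-bromophenyl in place of 4-fluorophenyl gives a 3.6-fold lower number from compound 2 to compound 3 (0.56 log units; beyond the scatter). Both steps are modest but lie beyond the scatter, unlike the earlier fluoro step. No evidence is available to account for this shift. From the compounds shown here alone, whether a 4-bromophenyl or 3-fluorophenyl group on this nitrogen would give a similar number stays open, so the effects of the halogen and its ring position cannot yet be separated.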